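The source may hold more compounds than are shown below. What is called first, only, known or untested is meant among the compounds shown, and "the series" means these compounds.

Compound 1 `O=C1C=C(NC2CCCCC2)C(=O)c2c1nc1n2[C@H]2OC[C@@H](O)[C@H]2OC1` and compound 3 `O=C1C(NC2CCCCC2)=CC(=O)c2c1nc1n2[C@H]2OC[C@@H](O)[C@H]2OC1` share the same atoms joined differently; the difference between the two cores is not broken down here. In a functional assay on MGC-803 cells (Homo sapiens) for inhibition, read by sulforhodamine B assay (on this read-out higher numbers stand for weaker inhibition and lower numbers for stronger inhibition), compound 1 gives only a limit of the assay, > 8000 nM. Compound 3 likewise reaches only a limit in this assay, > 8000 nM. Compound 2 `CCOc1ccccc1NC1=CC(=O)c2nc3n(c2C1=O)[C@H]1OC[C@@H](O)[C@H]1OC3` differs from compound 1 by 2-ethoxyphenyl in place of cyclohexyl on an amine nitrogen, and in this assay compound 2 gives 2450 nM, a step of an at least 3.2-fold lower number from compound 1 to compound 2 (0.51 log units; beyond the scatter). The same change turns compound 3 into compound 4 `CCOc1ccccc1NC1=CC(=O)c2c(nc3n2[C@H]2OC[C@@H](O)[C@H]2OC3)C1=O`: 2-ethoxyphenyl in place of cyclohexyl on an amine nitrogen. Because of the limit of > 8000 nM in this assay, at which 2 of the 3 values shown sit, the step from compound 1 sets only a floor on its size. Compound 4 is therefore expected to show a step of an at least 2.6-fold lower number from compound 3 to compound 4 (0.42 log units; beyond the scatter), resting on an at least 3.2-fold lower number from compound 1 to compound 2 (0.51 log units; beyond the scatter). The value of compound 4 in this assay is estimated at 3000 nM, between 1000 nM and 8000 nM.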

Compound 4, half-maximal inhibitory concentration: 2830 nM
Beside the measured number, compound 4's estimate is 1.1-fold (0.03 log units) above it; the range from low to high includes it.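

In this assay, replacing cyclohexyl with 2-ethoxyphenyl on an amine nitrogen of the core of compound 3 gives an at least 2.8-fold lower number from compound 3 to compound 4 (0.45 log units; beyond the scatter). The change therefore lowers the number on both cores, so its direction carries over in these two pairs: the same change on two cores in this assay, an at least 3.2-fold lower number (0.51 log units; beyond the scatter) from compound 1 to compound 2 and an at least 2.8-fold lower number (0.45 log units; beyond the scatter) from compound 3 to compound 4; the limit leaves it open whether they differ. The true size of neither step is shown, and no claim can be made that the change is worth the same on each core, as both steps start from a limit: the limit of > 8000 nM in this assay, at which 2 of the 4 values shown sit.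

The compounds shown leave open whether the ethoxy group or the aromatic ring accounts for the step, which a plain phenyl or a methoxyphenyl on that nitrogen could separate. They also leave open whether other groups there, such as a benzyl or a longer alkyl chain, would behave alike on both cores.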